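Trifluoromethoxy for Trifluoromethyl on Two Related Cores

The compounds below may be only part of what the source reports. "The series", "measured", "known", "first", "only" and "open" are said of these compounds alone.

Compound 1 `CC(O)(CSc1ccc(C(F)(F)F)cc1)C(=O)Nc1ccc(S(F)(F)(F)(F)F)cc1` and compound 2 `CC(O)(CSc1ccc(OC(F)(F)F)cc1)C(=O)Nc1ccc(S(F)(F)(F)(F)F)cc1` share one core and differ only at one ring. In a functional assay on VCaP cells (Homo sapiens) for antiproliferative activity, read by propidium iodide staining, with a stated time of 96 h (a higher number here means a weaker inhibitor, a lower number a stronger inhibitor), compound 1 gives 24800 nM, and compound 2 gives 16000 nM. The change between them is trifluoromethoxy in place of trifluoromethyl on an aromatic carbon and it made a 1.6-fold lower number from compound 1 to compound 2 (0.19 log units; within the scatter).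

Compound 3 `CC(O)(COc1ccccc1C(F)(F)F)C(=O)Nc1ccc(S(F)(F)(F)(F)F)cc1` has a different core; how its core differs from that of compound 1 is not broken down here. In this assay compound 3 gives 3100 nM, the lowest number of the three measured, beyond the scatter from both of the others.

Compound 4 `CC(O)(COc1ccccc1OC(F)(F)F)C(=O)Nc1ccc(S(F)(F)(F)(F)F)cc1` is not yet measured. It differs from compound 3 by trifluoromethoxy in place of trifluoromethyl on an aromatic carbon. This is the same kind of change as from compound 1 to compound 2, though the place differs: ortho to a large group here, para to a large group there.

Because the earlier step was a 1.6-fold lower number from compound 1 to compound 2 (0.19 log units; within the scatter), a step of similar small size is expected, namely a 1.3-fold lower number from compound 3 to compound 4 (0.11 log units; within the scatter). Compound 4 is estimated in this assay at 2400 nM, expected to fall between 900 nM and 6500 nM.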

Compound 4, half-maximal inhibitory concentration: 9700 nM
Estimate against measurement, compound 4: 4.0-fold (0.61 log units) below; the measured number lies above the stated range.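

In this assay, trifluoromethoxy in place of trifluoromethyl gave a 3.1-fold higher number from compound 3 to compound 4 (0.50 log units; beyond the scatter), so the change that made no clear difference on the core of compound 1 was not neutral on the core of compound 3. Among the compounds shown here, the effect of this change therefore did not carry over unchanged between these two cores: the same change on two cores in this assay, a 1.6-fold lower number (0.19 log units; within the scatter) from compound 1 to compound 2 and a 3.1-fold higher number (0.50 log units; beyond the scatter) from compound 3 to compound 4, 4.9-fold (0.69 log units) apart, beyond the scatter of two such steps This does not show which structural difference between the cores accounts for the gap, nor does it establish a general rule for the series, as each core contributes only a single pair, and the two pairs also differ in where the group sits on the ring.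

The compounds shown leave open how the same change behaves on the core of compound 1 when the group sits ortho to a large group, which would separate the role of the place from that of the rest of the core. They also leave open whether a methoxy or a nitrile at that place on the core of compound 3 would follow either step.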